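Bromo in Place of Phenoxy on the Arylidene Ring

The source may hold more compounds than are shown below. What is called first, only, known or untested is meant among the compounds shown, and "the series" means these compounds.

Measured so far:
compound 1 `O=C1/C(=C\c2c(Cl)cccc2Cl)c2ccccc2N1c1c(Cl)cccc1Cl` — > 100 ug/mL
compound 2 `O=C1/C(=C\c2cccc(Oc3ccccc3)c2)c2ccccc2N1c1c(Cl)cccc1Cl` — > 100 ug/mL

Both compounds share one core and differ only in the ring attached to the exocyclic double bond. In a functional assay on B16-F10 cells (Homo sapiens) for cytotoxicity against B16-F10 (Mus musculus), read by MTT assay, with a stated time of 72 h (on this read-out lower numbers stand for an effect already at smaller amounts and higher numbers for an effect only at larger amounts of compound), compound 1 gives > 100 ug/mL, which is a limit of the assay and not a number. In the same assay compound 2 gives > 100 ug/mL, again only a limit. Compound 2 therefore cannot be placed on a scale of numbers; it simply sits at the limit of > 100 ug/mL in this assay, at which 2 of the 2 values shown sit, together with every other value shown.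

Compound 3 `O=C1/C(=C\c2cccc(Br)c2)c2ccccc2N1c1c(Cl)cccc1Cl` is the next compound to be tested. It differs from compound 2 by bromo in place of phenoxy on an aromatic carbon. Among the measured compounds shown here, no measured pair shows what this exchange does to the read-out. With both measured compounds at the limit, the expected step of a number no higher from compound 2 to compound 3 (the limit leaves the size open) is none beyond the scatter, most likely ending at the same limit. Compound 3 is estimated at 100 ug/mL, within 30 ug/mL to 300 ug/mL.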

Compound 3, concentration for half-maximal effect: 8 ug/mL
Estimate against measurement, compound 3: 13-fold (1.10 log units) above, outside the stated range (below it).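

In this assay, the aromatic carbon on the ring attached to the exocyclic double bond turns out to matter: bromo in place of phenoxy gives an at least 12-fold lower number from compound 2 to compound 3 (1.09 log units; beyond the scatter). The ring as a whole matters too, as 3-bromophenyl in place of 2,6-dichlorophenyl gives an at least 12-fold lower number from compound 1 to compound 3 (1.09 log units; beyond the scatter). Compound 3 is the only compound here with a true number, while compound 1 and compound 2 stop at a limit of the assay: the limit of > 100 ug/mL in this assay, at which 2 of the 3 values shown sit.

From the compounds shown here alone, the true size of both steps stays open, as each starts from a limit and not from a number. The compounds shown also cannot separate what bromo adds from what the loss of phenoxy removes, and they offer no chloro, methoxy or amine on this carbon for comparison.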